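The compounds below may be only part of what the source reports. "The series", "measured", "known", "first", "only" and "open" are said of these compounds alone.

Measured so far:
Compound 1 `Cn1ccc2ccc(-c3cc(Nc4ccccc4S(=O)(=O)Nc4cncnc4)cc4nccnc34)cc21` gives 0.683 h
Compound 2 `CN1CCCC(NS(=O)(=O)c2ccccc2Nc2cc(-c3ccc4ccn(C)c4c3)c3nccnc3c2)C1` gives 0.483 h

For the measured compounds named here, compound 2 stands at 0.483 h in an ADME assay on microsomes from liver (Mus musculus, strain CD-1) for metabolic stability, read by LC-MS, tested at 2 uM (on this read-out higher numbers stand for a longer-lived compound and lower numbers for a shorter-lived compound), and has only one measured neighbour, lying within the scatter of compound 1 at 0.683 h on this scale.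

The next compound, compound 3 `CN(Cc1cncnc1)S(=O)(=O)c1ccccc1Nc1cc(-c2ccc3ccn(C)c3c2)c2nccnc2c1`, keeps the shared core and differs at one place, with methyl((pyrimidin-5-yl)methyl)amino in place of (1-methylpiperidin-3-yl)amino on a sulfonyl sulfur. The counted difference reads methyl((pyrimidin-5-yl)methyl)amino in place of (1-methylpiperidin-3-yl)amino on a sulfonyl sulfur and nothing else changes.

Going by the values given here, only one measured step bears on this, namely a 1.4-fold lower number from compound 1 to compound 2 (0.15 log units; within the scatter) for 1-methylpiperidin-3-yl in place of pyrimidin-5-yl on a sulfonamide nitrogen. Among the compounds with values here, compound 3 brings pyrimidin-5-yl back, but in a new form, and no measured compound tests the methyl or methyl((pyrimidin-5-yl)methyl)amino itself. With a single small step to go on, no step beyond the scatter is expected, and the range must stay wide.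

The estimate amounts to a 1.1-fold lower number from compound 2 to compound 3 (0.03 log units; within the scatter) as the expected step in this assay and no clear direction is expected.

Compound 3 is expected at about 0.45 h with an estimated range from 0.2 h to 0.95 h in this assay for repeat measurements.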

Compound 3, half-life: 0.2 h
The estimate for compound 3 lay 2.3-fold (0.35 log units) above the measured number, within the range that was stated.
By their numbers in this assay, from the lowest: compound 3; then compounds 2 and 1 (each within the scatter of the next).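

In this assay, the group on the sulfonyl sulfur now makes a difference larger than the usual scatter: methyl((pyrimidin-5-yl)methyl)amino in place of (1-methylpiperidin-3-yl)amino gives a 2.4-fold lower number from compound 2 to compound 3 (0.38 log units; beyond the scatter). The same group in place of (pyrimidin-5-yl)amino gives a 3.4-fold lower number from compound 1 to compound 3 (0.53 log units; beyond the scatter), so the return of the pyrimidine ring does not by itself bring back the half-life of compound 1, and how the ring is attached to the sulfonyl sulfur matters as well. For the compounds shown here, by the printed counts, the group entering in compound 3 has no hydrogen-bond donor, unlike the one it replaces in compound 2, but no measurement here explains why the compound is shorter-lived in these microsomes.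

Compound 3 differs from compound 1 both by a methyl on the sulfonamide nitrogen and by an extra carbon link to the ring, so the compounds shown cannot say which of the two goes with the lower number; ((pyrimidin-5-yl)methyl)amino, without the methyl, would separate them. Also open, on these data alone, is where a small group with no ring, such as dimethylamino, would fall on this scale.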